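The compounds below may be only part of what the source reports. "The series", "measured", "known", "first", "only" and "open" are said of these compounds alone.

In an ADME assay for permeability, using PAMPA, at pH 7.4 (a higher number here means that the compound crosses the layer faster, a lower number that the compound crosses the layer more slowly), compound 1, `O=C(O)COc1cc(Cl)c(C(=O)Nc2cccc(-c3nc4ccccc4s3)c2)cc1[N+](=O)[O-]`, gives < 1 10^-6 cm/s, which is a limit of the assay and not a number. Compound 2, `O=C(Nc1nc2c(Cl)cccc2s1)c1cc([N+](=O)[O-])ccc1Cl`, gives a true reading of 242 10^-6 cm/s, so the same assay can report high values. Compound 3, `COc1cc(Cl)c(C(=O)Nc2cccc(-c3nc4ccccc4s3)c2)cc1[N+](=O)[O-]`, has yet to be measured. It differs from compound 1 in one place: hydrogen in place of carboxy on a saturated chain carbon bound to an oxygen on an aromatic ring. Hydrogen takes the place of carboxy on a saturated chain carbon bound to an oxygen on an aromatic ring, which turns carboxymethoxy into methoxy. Going by the values given here, no measured pair shows this change directly, so the expectation is a loose one. An upward step beyond the usual scatter is expected, estimated as an at least 30-fold higher number from compound 1 to compound 3 (1.47 log units; beyond the scatter). For compound 3 the estimated value is 30 10^-6 cm/s, with an expected range from 3 10^-6 cm/s to 200 10^-6 cm/s.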

Compound 3, apparent permeability: 12 10^-6 cm/s
Estimate against measurement, compound 3: 2.5-fold (0.40 log units) above, within the range that was stated.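

Replacing carboxymethoxy with methoxy, with the rest of the molecule unchanged, gives an at least 12-fold higher number from compound 1 to compound 3 (1.07 log units; beyond the scatter). Going by these compounds alone, this is the first sign that this one place, a saturated chain carbon bound to an oxygen on an aromatic ring, can decide whether this assay gives a true reading for this core. Compound 1 gives < 1 10^-6 cm/s, which is a limit of the assay and not a number, so the true size of the step remains unknown and it may be larger than stated, because compound 1 sits at that limit: the limit of < 1 10^-6 cm/s in this assay, at which 1 of the 3 values shown sits.

From the compounds shown here alone, only carboxy and hydrogen are compared here, so it remains open whether an amine or a longer chain in the same place would read like compound 1 or like compound 3. Going by these compounds, it is also open whether the same change would act alike on another core, since compound 2 differs from these compounds in more than one place.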